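Replacing the thioether aryl group of compound 1

This account rests on a few compounds, and the source may have more. Where it says the series, first, only, none or still open, it means among the compounds named here.

Compound 1 `O=C(CSc1nc2ccccc2[nH]1)Nc1ccc2nc(NC(=O)c3ccc(C(F)(F)F)cc3)sc2c1` is the reference point of this set. Going by the values given here, in a functional assay on HCT-116 cells (Homo sapiens) for antiproliferative activity, read by MTT assay, with a stated time of 72 h (a higher number here means a weaker inhibitor, a lower number a stronger inhibitor), compound 1 gives 3760 nM, the lowest of the three numbers so far. Compound 2 `CCn1c(CNc2ccc(OC)cc2)nnc1SCC(=O)Nc1ccc(Cl)cc1` gives 39500 nM and compound 3 `Cn1c(CNC(=O)c2cccs2)nnc1SCC(=O)Nc1ccc(Cl)cc1` gives 91400 nM; both of these stand well beyond the scatter from compound 1, so compound 1 is the strongest inhibitor of the three measured compounds, while compounds 2 and 3 share only the thioacetamide anilide motif with it and differ elsewhere, so no single step can be read between them.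

Compound 4 `O=C(CSc1ccc(Cl)cc1)Nc1ccc2nc(NC(=O)c3ccc(C(F)(F)F)cc3)sc2c1` is the next compound to be tested. It keeps the core of compound 1 and changes one place: 4-chlorophenyl in place of 1H-benzimidazol-2-yl on a sulfur. Among the compounds with values here, no measured pair shows this change, so its size cannot be taken from the data. A step in the weaker direction, but of moderate size, is expected, giving a 1.9-fold higher number from compound 1 to compound 4 (0.27 log units; within the scatter). Compound 4 is therefore estimated at 7000 nM, with a range from 2000 nM to 25000 nM.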

Compound 4, half-maximal inhibitory concentration: 930 nM
Compound 4: middle estimate off by 7.5-fold (0.88 log units), on the high side; measured number below the stated range.
By their numbers in this assay, from the lowest: compound 4; then compound 1; then compound 2; then compound 3.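

In this assay, going by these compounds alone, 4-chlorophenyl in place of 1H-benzimidazol-2-yl on a sulfur gives a 4.0-fold lower number from compound 1 to compound 4 (0.61 log units; beyond the scatter), the first reading of any change at this position. In this pair, the number falls even though the entering group has no hydrogen-bond donor or acceptor and no five-membered aromatic ring, so neither feature of 1H-benzimidazol-2-yl is required for activity in compound 4. No supporting measurement accounts for the size or direction of this step.

Still open, on these data alone, is whether the chlorine contributes to the step, which plain phenyl on the same sulfur would help to settle. Also open, as far as these compounds go, is whether an aromatic ring is needed here at all, a question that cyclohexyl on the same sulfur would address.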